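Changing the benzyl ring on a level pair

The compounds below may be only part of what the source reports. "The series", "measured", "known", "first", "only" and "open" are said of these compounds alone.

In a functional assay on A-375 cells (Homo sapiens) for antiproliferative activity, read by MTT assay, with a stated time of 24 h (a higher number here means a weaker inhibitor, a lower number a stronger inhibitor), compound 1 `COc1cc(OC)c(-c2coc3cc(OCc4ccccc4C)ccc3c2=O)cc1OC` gives 1360 nM and compound 2 `COc1cc(OC)c(-c2coc3cc(OCc4cccc(F)c4)ccc3c2=O)cc1OC` gives 1300 nM, so the two stand level within the scatter. Compound 3 `COc1cc(OC)c(-c2coc3cc(OCc4ccc(Cl)cc4)ccc3c2=O)cc1OC` keeps the shared core and carries 4-chlorophenyl in place of the 3-fluorophenyl of compound 2: 4-chlorophenyl in place of 3-fluorophenyl on a saturated chain carbon bound to an oxygen on an aromatic ring. Among the measured compounds shown here, only one measured step bears on this place, a 1.0-fold lower number from compound 1 to compound 2 (0.02 log units; within the scatter), and it was too small to read beyond the scatter. One such step is thin evidence, but no shift beyond the scatter is expected in this assay, and the expected change is a 1.1-fold lower number from compound 2 to compound 3 (0.03 log units; within the scatter). For compound 3 the estimated value is 1200 nM, with a range of 500 nM to 2800 nM.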

Compound 3, half-maximal inhibitory concentration: 1020 nM
The estimate for compound 3 lay 1.2-fold (0.07 log units) above the measured number; the measured number falls inside the stated range.
By their numbers in this assay, from the lowest: compounds 3, 2 and 1 (each within the scatter of the next).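

In this assay a third ring, 4-chlorophenyl, still moves the number very little: there is a 1.3-fold lower number from compound 2 to compound 3 (0.11 log units; within the scatter), and a 1.3-fold lower number from compound 1 to compound 3 (0.12 log units; within the scatter). Across 2-methylphenyl, 3-fluorophenyl and 4-chlorophenyl, then, this place holds a methyl, a fluorine or a chlorine on the ring with no readable change in the number. No measured evidence is available to explain this level result. Going by these compounds, it remains open whether the picture stays this flat for a ring carrying an amine or a carboxylic acid, or for a longer chain joining the ring to the oxygen.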